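The source may report more compounds than this note shows. Statements on the series, on what has been measured and on what is new or still open speak of the compounds shown alone.

Measured compounds:
compound 1, `C[C@@]1(c2ccc3c(N)ncnn23)O[C@H](CO)[C@@H](O)[C@H]1O`, giving 0.0508 nM in an in vivo ADME assay on the whole organism (Huh-7 cells, Homo sapiens) for pharmacokinetics, read by LC-MS, with a stated time of 24 h, tested at 10 uM, at a dose of 10 uM; on this read-out lower numbers stand for lower exposure and higher numbers for higher exposure at the dose given;
compound 2, `C=C[C@@]1(c2ccc3c(N)ncnn23)O[C@H](CO)[C@@H](O)[C@H]1O`, giving 0.002 nM in this assay.

Compound 2 stands at the lowest of the two numbers in this assay. Within the data shown here, its nearest neighbour is compound 1, and the single measured step, a 25-fold lower number from compound 1 to compound 2 (1.40 log units; beyond the scatter), separates the two. Compound 3, `C#C[C@@]1(c2ccc3c(N)ncnn23)O[C@H](CO)[C@@H](O)[C@H]1O`, is not yet measured in this assay. It differs from compound 2 in one place: ethynyl in place of vinyl on a saturated ring carbon. Among the measured compounds shown here, only one measured step exists, and it concerns a different change, vinyl in place of methyl on a saturated ring carbon, with the large size a 25-fold lower number from compound 1 to compound 2 (1.40 log units; beyond the scatter). For the measured compounds named here, no measured pair shows what ethynyl in place of vinyl on a saturated ring carbon does, so the direction of the new step cannot be read from the data. He therefore expects no step beyond the scatter, a 1.3-fold higher number from compound 2 to compound 3 (0.10 log units; within the scatter), and treats it with caution. For compound 3 the estimate in this assay is 0.0025 nM, with a range from 0.0006 nM to 0.012 nM.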

Compound 3, maximal plasma concentration: 0.00066 nM
Compound 3: the middle estimate sits 3.8-fold (0.58 log units) above what was measured, within the range that was stated.
By their numbers in this assay, from the lowest: compound 3; then compound 2; then compound 1.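

At this saturated ring carbon, next to the ring oxygen, replacing vinyl with ethynyl in this assay gives a 3.0-fold lower number from compound 2 to compound 3 (0.48 log units; beyond the scatter), so two groups with the same count of heavy atoms, neither carrying a hydrogen-bond donor or acceptor, still differ beyond the scatter. Replacing methyl with ethynyl at the same place gives a 77-fold lower number from compound 1 to compound 3 (1.89 log units; beyond the scatter), which shows that the position responds to more than the single change seen before and puts the three groups in one order, from methyl through vinyl to ethynyl, with no compound shown going against it. No measurement shown here explains why the numbers differ.

The compounds shown leave open where an ethyl group, a longer chain such as propyl, or an aminomethyl group would fall at this ring carbon, and so whether the order holds beyond these three groups. They also leave open whether the same changes would give steps of similar size on a core carrying other groups at its neighbouring hydroxy or hydroxymethyl positions.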